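A few compounds are considered here, and "the series" means these few. Any claim that something is new, unique, unknown or untested is made for them only; others in the source may bear on it.

Among the measured compounds shown here, in an ADME assay on microsomes (Homo sapiens) for metabolic stability (a higher number here means that the compound lasts longer, a lower number that the compound disappears faster), compound 3 `CC(C)(C)NS(=O)(=O)c1ccc(-c2sc(C(=O)N[C@H]3C[C@H](C(=O)O)C3)nc2CC2CCCCC2)c(Cl)c1` gives 1.68 h, the second highest of the three numbers so far. Compound 1 `CC(C)NS(=O)(=O)c1ccc(-c2sc(C(=O)N[C@H]3C[C@H](C(=O)O)C3)nc2CC2CCCCC2)c(C(F)F)c1Cl` gives 1.88 h, nearest to compound 3 and within the scatter of it. Compound 2 `CC(C)(C)NS(=O)(=O)c1ccc(-c2sc(C(=O)N3CC4(C3)CS(=O)(=O)C4)nc2CC2CCCCC2)c(Cl)c1Cl` gives 0.3 h, the furthest from compound 3 and beyond the scatter. Compound 4 `CC(C)(C)NS(=O)(=O)c1ccc(-c2sc(C(=O)N[C@H]3C[C@H](C(=O)O)C3)nc2CC2CCCCC2)c(C(F)(F)F)c1` is not yet measured; it differs from compound 3 by trifluoromethyl in place of chloro on an aromatic carbon, ortho to a large group and meta to a (tert-butyl)sulfamoyl group. For the measured compounds named here, no two measured compounds differ in one place only, so no single-change step is known. In this assay the expected step of a 1.1-fold lower number from compound 3 to compound 4 (0.02 log units; within the scatter) is none beyond the scatter. Compound 4 is therefore estimated at 1.6 h, within a range from 0.7 h to 3.5 h.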

Compound 4, half-life in the Homo sapiens assay: > 3 h
Compound 4: only a limit was reported; the forecaster's own chance of this, stated with the estimate: 5%; middle value at least 1.8-fold (0.27 log units) away from the limit.
By their numbers in the Homo sapiens assay, from the lowest: compound 2; then compounds 3 and 1 (each within the scatter of the next). At a limit, above all of these: compound 4.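

In the Homo sapiens assay compound 3 gives 1.68 h. In the Homo sapiens assay compound 4 gives > 3 h, which is a limit of the assay, not a number: the limit of > 3 h in the Homo sapiens assay, at which 1 of the 4 values shown sits. In the Homo sapiens assay, trifluoromethyl in place of chloro on the aromatic carbon ortho to a large group gives an at least 1.7-fold higher number from compound 3 to compound 4 (0.25 log units; that floor lies within the scatter). This place therefore carries trifluoromethyl, with 4 heavy atoms against 1 for chloro, without any loss of half-life.

As far as these compounds go, whether the true step lies beyond the scatter stays open, as does how a nitrile or a methoxy group would read at this place. In a physicochemical assay for solubility, read by HPLC, in phosphate buffer, measured as thermodynamic solubility, with a stated time of 5 days, at pH 2, tested at 10 mM (on this read-out lower numbers stand for lower solubility and higher numbers for higher solubility), compound 3 gives < 1000 nM, which is a limit of the assay, not a number: the limit of < 1000 nM in the physicochemical assay, at which 1 of the 2 values shown sits. In the physicochemical assay compound 4 gives < 4000 nM, which is also a limit of the assay, not a number: the limit of < 4000 nM in the physicochemical assay, at which 1 of the 2 values shown sits. In the physicochemical assay the step between these two compounds cannot be read.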